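A Chlorostyryl Group Replaces Hydroxymethyl on a Phenol

This account rests on a few compounds, and the source may have more. Where it says the series, first, only, none or still open, it means among the compounds named here.

Compound 1 `C=C[C@@](C)(/C=C/c1ccc(O)cc1)CC/C=C(\C)C(=O)OCC` and compound 2 `C=C[C@@](C)(/C=C/c1ccc(O)c(CO)c1)CCC=C(C)C` were both tested in a functional assay on HepG2 cells (Homo sapiens) for cytotoxicity, with a stated time of 72 h; on this read-out lower numbers stand for an effect already at smaller amounts and higher numbers for an effect only at larger amounts of compound. Compound 1 gives only a limit in this assay, > 52000 nM. Compound 2 likewise returns only a limit in this assay, > 52000 nM. Compound 2 thus stands at the threshold of the assay rather than at a number, the same position held by every value shown (the limit of > 52000 nM in this assay, at which 2 of the 2 values shown sit). Compound 3 `C=C[C@@](C)(/C=C/c1ccc(O)c(/C=C/c2ccc(Cl)cc2)c1)CCC=C(C)C` differs from compound 2 in one place: 2-(4-chlorophenyl)ethenyl in place of hydroxymethyl on an aromatic carbon. For the measured compounds named here, no measured pair covers such a change, so the size of the step is open. In this assay the step from compound 2 to compound 3 is estimated at an at least 1.1-fold lower number from compound 2 to compound 3 (0.06 log units; that floor lies within the scatter), which is not expected to go beyond the scatter. Compound 3 is expected to give about 45000 nM in this assay, within a range from 12000 nM to 150000 nM, with a fair chance that only a limit is reported once more.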

Compound 3, half-maximal effective concentration: > 52000 nM
Compound 3: no number, only a limit (the forecaster's own chance of this, stated with the estimate: 60%); at least 1.1-fold (0.06 log units) between middle value and limit.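

In this assay compound 3 returns only a limit, as compound 2 does, so no step can be read between compound 2 and compound 3: the limit of > 52000 nM in this assay, at which 3 of the 3 values shown sit. The compounds shown leave open at what concentration, if any, any of them reaches a half-maximal effect on these cells.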